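This account rests on a few compounds, and the source may have more. Where it says the series, first, only, none or still open, it means among the compounds named here.

In an assay on isolated protein for inhibition of Indoleamine 2,3-dioxygenase 1 (Homo sapiens), read by spectrophotometry (on this read-out lower numbers stand for stronger inhibition and higher numbers for weaker inhibition), compound 1 `O=C(Cc1cccnc1)c1cc2cc(-c3ccccc3)ccc2[nH]1` gives 96000 nM, the highest number among the three measured compounds. Compound 3 `COc1cccc2[nH]c(C(=O)Cc3cccnc3)cc12` gives 58000 nM, which lies within the usual scatter of the number for compound 1, whereas compound 2 `O=C(Cc1ccccn1)c1cc2ccccc2[nH]1` gives 37000 nM, a gap that goes beyond the scatter. For the measured compounds named here, no step between two measured compounds differing in a single place is available here. Compound 4 `O=C(Cc1cccnc1)c1cc2cc(Br)ccc2[nH]1` differs from compound 1 by bromo in place of phenyl on an aromatic carbon. Without a single-change step to lean on, the change from compound 1 to compound 4 is expected to be modest, most likely toward a somewhat lower number that need not exceed the scatter. The estimate for compound 4 in this assay is 60000 nM, from 20000 nM to 180000 nM, which corresponds to an expected 1.6-fold lower number from compound 1 to compound 4 (0.20 log units; within the scatter).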

Compound 4, half-maximal inhibitory concentration: 18000 nM
Estimate against measurement, compound 4: 3.3-fold (0.52 log units) above; measured number below the stated range.
By their numbers in this assay, from the lowest: compound 4; then compounds 2, 3 and 1 (each within the scatter of the next, the first and the last beyond it).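

In this assay, for the compounds shown here, bromo in place of phenyl on an aromatic carbon gives a 5.3-fold lower number from compound 1 to compound 4 (0.73 log units; beyond the scatter) and is the first single-place change available for this series. It shows that the number responds to the group at this position, meta to a fused ring and para to a fused ring, and that a single bromine atom here gives a lower number than the six-carbon ring. No measurement bears on why this happens. The compounds shown leave open whether an amine, a methoxy group or a chloro group at this position would go lower still, and whether hydrogen alone would match bromo.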